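The compounds below may be only part of what the source reports. "The series", "measured", "known", "first", "only" and "open" are said of these compounds alone.

Compound 1 `O=C(Nc1nc2cc(Sc3ccccc3)ccc2[nH]1)OC1COC1` is the weaker of the two measured compounds in a functional assay on PC-3 cells (Homo sapiens) for cytotoxicity, read by MTT assay, with a stated time of 72 h, tested at 10 uM (on this read-out higher numbers stand for a weaker effect at the one concentration tested and lower numbers for a stronger effect), where compound 1 gives 87.8%. Compound 2 `COC(=O)Nc1nc2cc(C(=O)c3ccc(N(C)C4COC4)cc3)ccc2[nH]1` sits well beyond the scatter from that figure; in this assay compound 2 gives 33.6%. Compound 3 `CCCSc1ccc2[nH]c(NC(=O)OC3COC3)nc2c1` differs from compound 1 in a single place: propyl in place of phenyl on a sulfur. Among the measured compounds shown here, no measured pair shows this exchange, so the expected change in this assay is a number 1.8 percentage points lower from compound 1 to compound 3 (within the scatter), nothing beyond the scatter. Compound 3 is accordingly estimated at 86%, with a range from 68% to 100%.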

Compound 3, a percentage reported as activity, at one concentration (the size of the read-out at that concentration, not a potency): 84.5%
Beside the measured number, compound 3's estimate is 1.5 percentage points above it; measured number inside the range.
By their numbers in this assay, from the lowest: compound 2; then compounds 3 and 1 (each within the scatter of the next).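

In this assay the change from phenyl to propyl on the sulfur amounts to a number 3.3 percentage points lower from compound 1 to compound 3 (within the scatter). This first measured pair at this position shows that an open chain with fewer heavy atoms can take the place of the aromatic ring without the read-out moving beyond the scatter. Nothing available here offers an explanation for this result. Still open, going by these compounds, is whether a longer chain, or a chain ending in an amine or a carboxylic acid, on this sulfur would shift the read-out. Also open, on these data alone, is whether a carbonyl in place of the sulfur would change it.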